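A cyclobutyl swap at the measuring limit

This account rests on a few compounds, and the source may have more. Where it says the series, first, only, none or still open, it means among the compounds named here.

Measured in an ADME assay on CHO cells (Cricetulus griseus) for cytotoxicity, read by LDH release (on this read-out lower numbers stand for stronger inhibition and higher numbers for weaker inhibition), each reading a limit and not a number:
Compound 1 `CC(Sc1ccc(Cl)cc1Cl)C(=O)NCc1ccc(F)cc1` gives > 100000 nM
Compound 2 `CC(Oc1ccc(Cl)cc1Cl)C(=O)NC(C)(C)c1ccc(F)cc1` gives > 100000 nM
Compound 3 `CCC(NC(=O)C(C)Oc1ccc(Cl)cc1Cl)c1ccc(F)cc1` gives > 100000 nM

Compound 3 stands with the other two, and its reading is only a limit. The whole set shares one result: the limit of > 100000 nM in this assay, at which 3 of the 3 values shown sit. Compound 4 `CC(Oc1ccc(Cl)cc1Cl)C(=O)NC(c1ccc(F)cc1)C1CCC1` departs from compound 3 in one place: cyclobutyl in place of ethyl on a saturated chain carbon bound to an amide-type nitrogen and an aromatic carbon, with cyclobutyl in place of ethyl on a saturated chain carbon bound to an amide-type nitrogen and an aromatic carbon. Among the measured compounds shown here, no measured pair shows a change of this kind. With compound 3 reading > 100000 nM as a limit, no step beyond the scatter is expected in this assay, in either direction. The estimated step of a number no higher from compound 3 to compound 4 (the limit leaves the size open) is expected to stay within the scatter. Compound 4 is expected to read 100000 nM, with an estimated range from 50000 nM to 200000 nM, most likely as a limit again.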

Compound 4, half-maximal inhibitory concentration: > 100000 nM
Compound 4 gave a limit, no number (the forecaster's own chance of this, stated with the estimate: 85%); the middle value sits exactly at the limit.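

Among the compounds shown here, compound 3 and compound 4 both read only as limits in this assay, so no step between them can be read: the limit of > 100000 nM in this assay, at which 4 of the 4 values shown sit. The compounds shown leave open whether cyclobutyl in place of ethyl shifts the reading in this assay at all.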